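The source may hold more compounds than are shown below. What is called first, only, known or untested is meant among the compounds shown, and "the series" means these compounds.

Compound 1 `O=C(CCc1cccc2c1B(O)OC2)Nc1cccc(Br)c1`: in a functional assay on HCT-116 cells (Homo sapiens) for antiproliferative activity, read by MTT assay, with a stated time of 72 h (on this read-out higher numbers stand for weaker inhibition and lower numbers for stronger inhibition), compound 1 gives 1400 nM.
Compound 2 `C#Cc1cccc(NC(=O)CCc2cccc3c2B(O)OC3)c1`: in this assay compound 2 gives 3600 nM.
Compound 3 `O=C(CCc1cccc2c1B(O)OC2)Nc1cccc(-c2ccc(F)cc2)c1`: in this assay compound 3 gives 550 nM.

Among the measured compounds shown here, all three share one core and differ only in the single group carried on the anilide ring. Compound 3 has the lowest number of the three and so shows the strongest inhibition: a 2.5-fold lower number from compound 1 to compound 3 (0.41 log units; beyond the scatter), and a 6.5-fold lower number from compound 2 to compound 3 (0.82 log units; beyond the scatter). Exchanging bromo for ethynyl went the other way, a 2.6-fold higher number from compound 1 to compound 2 (0.41 log units; beyond the scatter).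

Compound 4 `O=C(CCc1cccc2c1B(O)OC2)Nc1cccc(-c2ccc(OC(F)(F)F)cc2)c1` keeps the 4-fluorophenyl framework of compound 3 but alters the group on that outer ring: trifluoromethoxy in place of fluoro on an aromatic carbon. For the measured compounds named here, none of the measured steps changes a substituent on this outer ring; each of them changes the group directly attached to the anilide ring. Going by the values given here, the measured steps therefore give no close precedent; they show only that a 4-fluorophenyl group brought a modest gain over bromo and over ethynyl. With no direct guide, the expectation for this assay is a small shift, probably within the scatter, a 1.1-fold lower number from compound 3 to compound 4 (0.04 log units; within the scatter). Compound 4 is accordingly estimated at 500 nM, with a range from 200 nM to 1500 nM.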

Compound 4, half-maximal inhibitory concentration: 730 nM
Estimate against measurement, compound 4: 1.5-fold (0.16 log units) below; low and high end bracket the measured number.
By their numbers in this assay, from the lowest: compounds 3, 4 and 1 (each within the scatter of the next, the first and the last beyond it); then compound 2.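

Putting trifluoromethoxy in place of fluoro on the outer ring gives, in this assay, a 1.3-fold higher number from compound 3 to compound 4 (0.12 log units; within the scatter), so compound 3 and compound 4 cannot be told apart on this read-out. This is the first change shown on the outer ring rather than on the anilide ring, and it shows that at this place, para to a large group, a single fluorine can give way to a group of 5 heavy atoms with 1 hydrogen-bond acceptor without a difference that stands clear of the scatter. Nothing available explains why the two compounds read alike.

From the compounds shown here alone, it remains open whether a more different group at this place, such as an amine or a carboxylic acid, would also stay within the scatter of compound 3 or would move the number clearly in either direction. Also open, going by these compounds, is how a plain phenyl ring carrying only hydrogen there, or a longer chain such as butoxy, would compare with compound 3 and compound 4.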